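Replacing 4-chlorophenyl with methyl on a carbonyl carbon

The source may report more compounds than this note shows. Statements on the series, on what has been measured and on what is new or still open speak of the compounds shown alone.

In a functional assay on MDA-MB-231 cells (Homo sapiens) for antiproliferative activity, read by MTT assay, with a stated time of 6 days (a higher number here means a weaker inhibitor, a lower number a stronger inhibitor), the measured compounds stand as follows:
- compound 1 `CC(=O)O[C@@H]1C=CC(=O)O[C@@H]1[C@@H](COC(=O)c1ccc(Cl)cc1)OC(C)=O` gives 1850 nM
- compound 2 `O=C1C=C[C@@H](OCc2ccccc2)[C@@H]([C@@H](COC(=O)/C=C/c2ccc([N+](=O)[O-])cc2)OCc2ccccc2)O1` gives 1550 nM
- compound 3 `O=C1C=C[C@@H](OC(=O)c2ccccc2)[C@@H]([C@@H](COC(=O)c2ccccc2)OC(=O)c2ccccc2)O1` gives 52300 nM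

Compound 1 and compound 2 lie within the usual scatter of each other, so neither can be ranked above the other. Compound 3 stands well beyond the scatter from both, with the higher number and so the weaker inhibition. Compound 4 `CC(=O)OC[C@@H](OC(C)=O)[C@H]1OC(=O)C=C[C@H]1OC(C)=O` has not yet been measured. It departs from compound 1 by methyl in place of 4-chlorophenyl on a carbonyl carbon and thus carries methyl in place of 4-chlorophenyl on a carbonyl carbon, a change of (4-chlorophenyl)carbonyl to acetyl. Among the compounds with values here, no measured pair differs in only one place, so the data do not isolate this change. The wide gap to compound 3 at 52300 nM shows only how far numbers can spread in this small set. A moderate move towards a higher number is expected, and the estimated step is a 2.4-fold higher number from compound 1 to compound 4 (0.39 log units; beyond the scatter) in this assay with much uncertainty. The estimate for compound 4 is 4500 nM with 900 nM to 25000 nM as its expected range.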

Compound 4, half-maximal inhibitory concentration: 7480 nM
Estimate against measurement, compound 4: 1.7-fold (0.22 log units) below; the measured number falls inside the stated range.
By their numbers in this assay, from the lowest: compounds 2 and 1 (each within the scatter of the next); then compound 4; then compound 3.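

In this assay, within the data shown here, the pair of compound 1 and compound 4 is the only one in the set that differs in a single place, and so it gives the first direct reading of this position. Methyl in place of 4-chlorophenyl on a carbonyl carbon produces a 4.0-fold higher number from compound 1 to compound 4 (0.61 log units; beyond the scatter), so the group at this position does affect the number, and the 4-chlorophenyl form is the stronger inhibitor of the two. Even so, compound 4 still gives 7480 nM without that aromatic ring, and nothing available explains the step.

The pair cannot separate the contribution of the chlorine from that of the aromatic ring, which plain phenyl in this place would help to do. On these data alone, how a longer chain such as butyl, or a phenyl ring carrying an amine or a carboxylic acid, would behave here also remains open.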